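Extending the Carbonyl Side Chain of Compound 2

The source may report more compounds than this note shows. Statements on the series, on what has been measured and on what is new or still open speak of the compounds shown alone.

Of the compounds shown here, two have so far been measured in an assay on isolated protein for antagonist activity at Bile acid receptor (Homo sapiens), read by HTRF, with a stated time of 30 min; on this read-out higher numbers stand for weaker inhibition and lower numbers for stronger inhibition. Compound 1 `CCc1cc(C(C)=O)c(OCc2ccccc2)cc1OCCCCCC(C)(C)c1nnn[nH]1` gives 1100 nM. Compound 2 `CCC(=O)c1cc(CC)c(OCCCCCC(C)(C)c2nnn[nH]2)cc1O` gives 8500 nM, the higher of the two numbers, so compound 2 inhibits less strongly than compound 1, and this gap lies beyond the scatter. The two compounds differ in several places at once, so no single change can be held responsible for that gap.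

Compound 3 `CCCCC(=O)c1cc(CC)c(OCCCCCC(C)(C)c2nnn[nH]2)cc1O` is the next member of the series. It differs from compound 2 in one place only: ethyl in place of hydrogen on a saturated chain carbon, two bonds along the chain from a carbonyl carbon. For the measured compounds named here, nothing measured so far shows what a change of this kind does in this assay, so the expectation can only be a cautious one. The step of a 1.7-fold lower number from compound 2 to compound 3 (0.23 log units; within the scatter) is expected to be modest, leaning toward a lower number but perhaps not reaching beyond the scatter. Compound 3 is therefore estimated at 5000 nM, with a range from 1500 nM to 15000 nM.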

Compound 3, half-maximal inhibitory concentration: 5400 nM
Beside the measured number, compound 3's estimate is 1.1-fold (0.03 log units) below it; the measured number falls inside the stated range.
By their numbers in this assay, from the lowest: compound 1; then compounds 3 and 2 (each within the scatter of the next).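

Putting ethyl in place of hydrogen on a saturated chain carbon, two bonds along the chain from a carbonyl carbon, gives a 1.6-fold lower number from compound 2 to compound 3 (0.20 log units; within the scatter) in this assay. For the compounds shown here, this is the first step that changes one place only, and it shows that going from propanoyl to butylcarbonyl leaves the number indistinguishable from that of compound 2 on this read-out. No measurement shown here bears on the reason for this result.

Still open, on these data alone, is whether a much longer chain such as octyl, a phenyl ring, an amine or a carboxylic acid at this position would move the number beyond the scatter. One step also cannot show whether the same ethyl addition would give a similar result on the core of compound 1.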